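The source may report more compounds than this note shows. Statements on the series, on what has been measured and on what is new or still open speak of the compounds shown alone.

Three compounds have so far been measured in a functional assay for inhibition of Monoamine oxidase (Rattus norvegicus), tested at 0.1 uM; on this read-out lower numbers stand for a weaker effect and higher numbers for a stronger effect at the one concentration tested:

compound 1, `O=C(NC1=NCCN1)c1ccccc1`, gives 0%;
compound 2, `c1cnc2ccc(C3=NCCN3)cc2c1`, gives 0%;
compound 3, `c1ccc([C@H]2O[C@H]2C2=NCCN2)cc1`, gives 25%.

Compound 3 stands highest of the three numbers in this assay. Its nearest neighbour, compound 1, lies lower by a gap that is beyond the usual scatter of this kind of measurement, and compound 2, the furthest, lies lower by the same gap, also beyond the scatter. Compound 1 and compound 2 are built quite differently from compound 3, so neither pair tells how a small change to compound 3 alone would show up in this assay.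

Compound 4, `c1ccc([C@H]2O[C@@H]2C2=NCCN2)cc1`, has not yet been measured in this assay. Compared with compound 3, (the two compounds have the same atoms and bonds and differ only in configuration as drawn: 1 of 2 stereo elements differ; a stereocentre at a saturated ring carbon is drawn S in compound 3 and R in compound 4).

Within the data shown here, no pair of measured compounds differs in a single place, so there is no measured step to gauge how large an effect a change of configuration at one ring carbon might have. In this assay the expectation is a modest shift from the number of compound 3, in either direction, and quite possibly one that does not go beyond the scatter. For compound 4 the estimated value is 20%, with a range from 0% to 50%. This estimate means an expected step of a number 5 percentage points lower from compound 3 to compound 4 (within the scatter).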

Compound 4, a percentage reported as inhibition, at one concentration (the size of the read-out at that concentration, not a potency): 5%
Compound 4: middle estimate off by 15 percentage points, on the high side; the measured number falls inside the stated range.
By their numbers in this assay, from the lowest: compounds 1, 2 and 4 (each within the scatter of the next); then compound 3.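

In this assay, turning a single stereocentre at a saturated ring carbon from S to R gives a number 20 percentage points lower from compound 3 to compound 4 (beyond the scatter). Among these compounds, this is the first step in the set between two compounds that differ in one place, and it shows that the number can move beyond the scatter with no atom or bond added or taken away, so the way this ring carbon is drawn in space matters on this read-out. The gap can be traced to one change alone: the fact that compounds 3 and 4 differ only in the configuration as drawn

The compounds shown leave open what the second stereocentre contributes, since it stays as drawn in this pair, and whether the preference for the S form at this carbon would hold in compounds that carry another group, such as a methyl group or a chlorine atom, on the shared core. The read-out is also taken at one concentration, so it gives the size of the effect at that concentration and says nothing about how potency differs between the two compounds.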